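The compounds below may be only part of what the source reports. "The series", "measured", "known", "first", "only" and "open" are said of these compounds alone.

Measured so far:
compound 1 `COc1ccc(-c2nc(C(F)(F)F)ccc2CNC(=O)C(C)c2ccc(NS(C)(=O)=O)c(F)c2)cc1OC` — 25.6 nM
compound 2 `CC(C(=O)NCc1ccc(C(F)(F)F)nc1-c1ccsc1)c1ccc(NS(C)(=O)=O)c(F)c1` — 2 nM

In an assay on CHO cells for antagonist activity at transient receptor potential cation channel subfamily V member 1 (Homo sapiens), read by FLIPR (a higher number here means a weaker inhibitor, a lower number a stronger inhibitor), compound 2 stands lowest of the two numbers; its nearest neighbour, compound 1, gives 25.6 nM. Compound 3 `CC(C(=O)NCc1ccc(C(F)(F)F)nc1-c1ccoc1)c1ccc(NS(C)(=O)=O)c(F)c1` is unmeasured; it differs from compound 2 by furan-3-yl in place of thiophen-3-yl on an aromatic carbon. Among the measured compounds shown here, the only measured step at this aromatic carbon is a 13-fold lower number from compound 1 to compound 2 (1.11 log units; beyond the scatter), a large one, but it swaps a six-membered ring for thiophen-3-yl and does not test thiophen-3-yl against furan-3-yl. A small step, within the scatter, is expected, a 1.8-fold higher number from compound 2 to compound 3 (0.24 log units; within the scatter). Compound 3 is estimated at 3.5 nM (range 1.2 nM to 10 nM).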

Compound 3, inhibition constant: 1.4 nM
Estimate against measurement, compound 3: 2.5-fold (0.40 log units) above, within the range that was stated.
By their numbers in this assay, from the lowest: compounds 3 and 2 (each within the scatter of the next); then compound 1.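

In this assay, furan-3-yl and thiophen-3-yl on this aromatic carbon cannot be told apart, with a 1.4-fold lower number from compound 2 to compound 3 (0.15 log units; within the scatter). The advantage over 3,4-dimethoxyphenyl is therefore not confined to thiophen-3-yl, since a second five-membered aromatic ring with 1 hetero atom gives an 18-fold lower number from compound 1 to compound 3 (1.26 log units; beyond the scatter). No measurement is available to explain these results. From the compounds shown here alone, whether unsubstituted phenyl reads like 3,4-dimethoxyphenyl or like the five-membered rings remains open. So does the outcome with a non-aromatic group here, such as morpholine or a small amine.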